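Pyrazine for pyridine on a triazole core

The compounds below may be only part of what the source reports. "The series", "measured", "known", "first", "only" and "open" are said of these compounds alone.

Compound 1 `O=C([C@H]1CCN1S(=O)(=O)c1c(F)c(F)c(F)c(F)c1F)N(Cc1ccc(C2CCCCC2)cn1)c1cc2[nH]ncc2cc1F` and compound 2 `O=C([C@H]1CCN1S(=O)(=O)c1c(F)c(F)c(F)c(F)c1F)N(Cc1cnc(C2CCCCC2)cn1)c1cc2[nH]ncc2cc1F` share one core and differ in a single group. In a functional assay on MDA-MB-231 cells (Homo sapiens) for antiproliferative activity, with a stated time of 72 h (a higher number here means that more compound is needed for the effect, a lower number that less compound is needed), compound 1 gives 2300 nM, and compound 2 gives 2000 nM. The change is 5-cyclohexylpyrazin-2-yl in place of 5-cyclohexylpyridin-2-yl on a saturated chain carbon bound to an amide-type nitrogen, and its step is a 1.2-fold lower number from compound 1 to compound 2 (0.06 log units; within the scatter). Compound 3 `O=C([C@H]1CCN1S(=O)(=O)c1c(F)c(F)c(F)c(F)c1F)N(Cc1ccc(C2CCCCC2)cn1)c1ccc2nn[nH]c2c1` carries a different core, described by a group of 9 heavy atoms (6 carbon, 3 nitrogen; one five-membered aromatic ring with 3 hetero atoms, one six-membered aromatic ring of carbon only) in place of a group of 10 heavy atoms (7 carbon, 2 nitrogen, 1 fluorine; one five-membered aromatic ring with 2 hetero atoms, one six-membered aromatic ring of carbon only), on an amide-type nitrogen, and in this assay compound 3 gives 6600 nM, a step of a 2.9-fold higher number from compound 1 to compound 3 (0.46 log units; beyond the scatter). Compound 4 `O=C([C@H]1CCN1S(=O)(=O)c1c(F)c(F)c(F)c(F)c1F)N(Cc1cnc(C2CCCCC2)cn1)c1ccc2nn[nH]c2c1` has not been measured; it differs from compound 3 by 5-cyclohexylpyrazin-2-yl in place of 5-cyclohexylpyridin-2-yl on a saturated chain carbon bound to an amide-type nitrogen, the same change seen from compound 1 to compound 2, at the same place. Because that earlier step was a 1.2-fold lower number from compound 1 to compound 2 (0.06 log units; within the scatter), the step from compound 3 to compound 4 is expected to be similarly small, a 1.2-fold lower number from compound 3 to compound 4 (0.08 log units; within the scatter). Compound 4 is therefore estimated at 5500 nM, expected to fall between 2500 nM and 12000 nM.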

Compound 4, half-maximal effective concentration: 2100 nM
The estimate for compound 4 lay 2.6-fold (0.42 log units) above the measured number, outside the stated range (below it).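

Swapping in 5-cyclohexylpyrazin-2-yl for 5-cyclohexylpyridin-2-yl on the core of compound 3 gives a 3.1-fold lower number from compound 3 to compound 4 (0.50 log units; beyond the scatter) in this assay, so the small step seen on the core of compound 1 did not carry over in size: the same change on two cores in this assay, a 1.2-fold lower number (0.06 log units; within the scatter) from compound 1 to compound 2 and a 3.1-fold lower number (0.50 log units; beyond the scatter) from compound 3 to compound 4, 2.7-fold (0.44 log units) apart, beyond the scatter of two such steps

The core change, read with the pyrazine in place, gives a 1.1-fold higher number from compound 2 to compound 4 (0.02 log units; within the scatter), and so its size depends on the group present: the same change on two cores in this assay, a 2.9-fold higher number (0.46 log units; beyond the scatter) from compound 1 to compound 3 and a 1.1-fold higher number (0.02 log units; within the scatter) from compound 2 to compound 4, 2.7-fold (0.44 log units) apart, beyond the scatter of two such steps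

These two pairs show that the two changes do not add up independently here, but they do not show why, nor how the swap would behave on any other core.

As far as these compounds go, whether a phenyl or pyrimidine ring in place of the pyrazine would behave in the same way stays open. So does the effect of a piperidine in place of the cyclohexyl ring.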